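This account rests on a few compounds, and the source may have more. Where it says the series, first, only, none or still open, it means among the compounds named here.

Two compounds of this series carry a measurement. In a functional assay on PC-3 cells (Homo sapiens) for cytotoxicity, read by MTT assay, with a stated time of 72 h (on this read-out lower numbers stand for stronger inhibition and higher numbers for weaker inhibition), compound 1 `O=C(Nc1ccc(Oc2ccnc3[nH]ccc23)c(F)c1)c1nn(-c2ccc(Br)cc2)ccc1=O` gives 40800 nM. In this assay compound 2 `Cc1ccc(-n2nc(C(=O)Nc3ccc(Oc4ncnc5[nH]ccc45)cc3)c(C)cc2=O)cc1` gives 9610 nM, the lowest of the two numbers; the gap to compound 1 lies beyond the usual scatter of repeated measurements, so compound 2 stands as the stronger of the pair.

Compound 3 `Cc1cc(=O)n(-c2cccc(C(F)(F)F)c2)nc1C(=O)Nc1ccc(Oc2ncnc3[nH]ccc23)cc1` has not yet been measured. It differs from compound 2 in one place: 3-(trifluoromethyl)phenyl in place of 4-methylphenyl on an aromatic nitrogen. For the measured compounds named here, no pair of measured compounds shows this change, so its size and direction in this assay remain open. The account expects a small step from compound 2 to compound 3, a 1.4-fold lower number from compound 2 to compound 3 (0.14 log units; within the scatter), not clearly beyond the scatter, because compound 2 already gives 9610 nM and nothing measured argues for a large move either way. Compound 3 is therefore estimated at 7000 nM, with a range from 2500 nM to 20000 nM.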

Compound 3, half-maximal inhibitory concentration: 3460 nM
For compound 3 the middle estimate is 2.0-fold (0.31 log units) above the measured one; the measured number falls inside the stated range.
By their numbers in this assay, from the lowest: compound 3; then compound 2; then compound 1.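

In this assay, 3-(trifluoromethyl)phenyl in place of 4-methylphenyl on the aromatic nitrogen gives a 2.8-fold lower number from compound 2 to compound 3 (0.44 log units; beyond the scatter), a modest step that shows this position responds to a change of its aryl group. For the compounds shown here, no earlier pair could show this, as compound 1 and compound 2 differ in more than one place. The entering group has more heavy atoms than the leaving one, but both have no hydrogen-bond donors or acceptors, and nothing available here accounts for the step.

This single step changes both the substituent on the phenyl ring and its place on that ring, so the two contributions stay unseparated. From the compounds shown here alone, how a plain phenyl, or a phenyl carrying an amine or a carboxylic acid, would behave at this position remains open.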